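The source may report more compounds than this note shows. Statements on the series, on what has been measured and on what is new or still open speak of the compounds shown alone.

Among the compounds with values here, in a functional assay on MDA-MB-231 cells (Homo sapiens) for antiproliferative activity, with a stated time of 4 days (on this read-out lower numbers stand for stronger inhibition and higher numbers for weaker inhibition), compound 1 `CCCCc1ccc2[nH]c(-c3ccc(OC)cc3)c(/C=N/NC(=O)c3ccc(Cl)cc3)c2c1` gives 90 nM and compound 2 `CCCCc1ccc2[nH]c(-c3ccc(OC)cc3)c(/C=N/NC(=O)c3ccc(F)cc3)c2c1` gives 19 nM, the lower of the two numbers so far. Within the data shown here, only one measured step bears on the next compound: a 4.7-fold lower number from compound 1 to compound 2 (0.68 log units; beyond the scatter), with fluoro in place of chloro on an aromatic carbon. Compound 3 `CCCCc1ccc2[nH]c(-c3ccc(OC)cc3)c(/C=N/NC(=O)c3ccc(OC)cc3)c2c1` changes that same carbon again: methoxy in place of fluoro on an aromatic carbon. In words, methoxy takes the place of fluoro on an aromatic carbon, para to a large group. Among the measured compounds shown here, no compound with methoxy at this place has been measured, and two values set no trend that could be extended to it. For the measured compounds named here, they show only that one swap here moved the number modestly, and that the one other group tried, in compound 1 at 90 nM, gave the higher number. A modest rise from the low number of compound 2 therefore seems more likely than a further fall, though a fall cannot be ruled out. The estimated step in this assay is a 3.2-fold higher number from compound 2 to compound 3 (0.50 log units; beyond the scatter). For compound 3 the expected value is 60 nM, with an estimated range of 15 nM to 240 nM.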

Compound 3, half-maximal inhibitory concentration: 61 nM
For compound 3 the middle estimate is 1.0-fold (0.01 log units) below the measured one, and the stated range covers the measured number.
By their numbers in this assay, from the lowest: compound 2; then compounds 3 and 1 (each within the scatter of the next).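

In this assay, within the data shown here, the third group tried on this aromatic carbon does not extend the low number of compound 2: methoxy in place of fluoro gives a 3.2-fold higher number from compound 2 to compound 3 (0.51 log units; beyond the scatter) and so joins chloro on the higher side, leaving fluoro as the only one of the three groups that stands apart, with its steps to both others beyond the scatter. Methoxy in place of chloro gives a 1.5-fold lower number from compound 1 to compound 3 (0.17 log units; within the scatter) and so, unlike the swaps away from fluoro, makes no difference that can be read, even though the two groups are of different kinds. Nothing available here accounts for why fluoro stands apart from chloro and methoxy.

Going by these compounds, it remains open whether any other group on this carbon, such as an amine, a hydroxyl, a nitrile or a trifluoromethyl, would match the number of compound 2 at 19 nM or would fall with compounds 1 and 3. On these data alone, it is also open whether the gap between fluoro and the other two groups would persist on a core carrying a longer chain in place of the present one.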